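A few compounds are considered here, and "the series" means these few. Any claim that something is new, unique, unknown or untested is made for them only; others in the source may bear on it.

Working notes on the series. In an ADME assay on HepG2 cells (Homo sapiens) for inhibition, read by fluorescence and resazurin assay, with a stated time of 72 h (on this read-out higher numbers stand for weaker inhibition and lower numbers for stronger inhibition), compound 1 (`CN1CCN(c2ccc(Nc3nccc(Nc4ccc5nc[nH]c5c4)n3)cc2)CC1`) gives > 25000 nM as a limit of the assay and not a number. Compound 2 (`NS(=O)(=O)c1ccc(Nc2nccc(Nc3ccc4nc[nH]c4c3)n2)cc1`) gives > 25000 nM as a limit too, so it has no number on this read-out. The evidence amounts to the limit of > 25000 nM in this assay, at which 2 of the 2 values shown sit, and nothing firmer. For the measured compounds named here, the only measured step is a step that the two limits leave unreadable from compound 1 to compound 2 and it sets no size for what follows.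

Compound 3 (`Cc1cnc(Nc2ccc(S(N)(=O)=O)cc2)nc1Nc1ccc2nc[nH]c2c1`) carries methyl in place of hydrogen on an aromatic carbon and the rest matches compound 2. Going by the values given here, no measured step covers this change. The expectation rests only on compound 2 with its limit > 25000 nM and so no step beyond the scatter is expected in either direction. The expected step is a number no higher from compound 2 to compound 3 (the limit leaves the size open) and it is only an estimate. For compound 3 the estimated value in this assay is 25000 nM with an expected range from 8000 nM to 50000 nM and a limit is again likely.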

Compound 3, half-maximal inhibitory concentration: 18000 nM
For compound 3 the middle estimate is 1.4-fold (0.14 log units) above the measured one, and the stated range covers the measured number.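

In this assay, for the compounds shown here, compound 3 is the first of the series to give a number and not a limit, so methyl on an aromatic carbon of a six-membered aromatic ring with 2 nitrogen is the first change here that yields a readable value. The change shows an at least 1.3-fold lower number from compound 2 to compound 3 (0.14 log units; that floor lies within the scatter), so only a floor can be stated for it, and that floor does not go beyond the scatter. The series as a whole still rests mostly on limits: the limit of > 25000 nM in this assay, at which 2 of the 3 values shown sit.

The compounds shown leave open whether ethyl, chlorine or methoxy at this position would give a lower number than methyl does. They also leave open whether methyl at the same place gives a number when 4-methylpiperazin-1-yl stands in place of sulfamoyl.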